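Trifluoromethyl for Fluoro on the Second Aryl Ring

A few compounds are considered here, and "the series" means these few. Any claim that something is new, unique, unknown or untested is made for them only; others in the source may bear on it.

Three compounds share one core. In a functional assay on B16-F10 cells (Mus musculus) for cytotoxicity, read by MTT assay, with a stated time of 48 h (on this read-out higher numbers stand for weaker inhibition and lower numbers for stronger inhibition), compound 2 `COc1ccc(N/C=C\C(=O)c2nc(-c3ccc(F)cc3)n3ccccc23)cc1` gives 2560 nM, the only number among the three shown. Compound 1 `Cc1cc2cc(N/C=C\C(=O)c3nc(-c4ccc(F)cc4)n4ccccc34)ccc2[nH]1` reaches only the limit > 30000 nM in this assay. Compound 3 `O=C(/C=C\Nc1ccc(F)cc1)c1nc(-c2ccc(F)cc2)n2ccccc12` likewise shows the limit > 30000 nM. On the ring held by the amine nitrogen, an at least 11-fold lower number from compound 1 to compound 2 (1.06 log units; beyond the scatter) and an at least 11-fold higher number from compound 2 to compound 3 (1.06 log units; beyond the scatter), whereas a step that the two limits leave unreadable from compound 1 to compound 3, because the limit of > 30000 nM in this assay, at which 2 of the 3 values shown sit, hides both ends of that step.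

Compound 4 `COc1ccc(N/C=C\C(=O)c2nc(-c3ccc(C(F)(F)F)cc3)n3ccccc23)cc1` differs from compound 2 on the other ring: trifluoromethyl in place of fluoro on an aromatic carbon. Within the data shown here, no measured step touches that ring, so only the number for compound 2 guides the expectation. A step of a 1.4-fold higher number from compound 2 to compound 4 (0.14 log units; within the scatter) is expected, within the scatter. Compound 4 is therefore expected to give 3500 nM, between 1000 nM and 15000 nM.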

Compound 4, half-maximal inhibitory concentration: > 30000 nM
Compound 4: only a limit was reported (the forecaster's own chance of this, stated with the estimate: 15%); at least 8.5-fold (0.93 log units) between middle value and limit.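

Among these compounds, the ring that stayed 4-fluorophenyl in the earlier compounds also bears on the read-out: in this assay, 4-(trifluoromethyl)phenyl in its place gives an at least 11-fold higher number from compound 2 to compound 4 (1.06 log units; beyond the scatter). Compound 4 gives > 30000 nM, which is a limit and not a number. The only readable value among the compounds shown therefore depends on both aryl rings, and the full size of this step stays hidden: the limit of > 30000 nM in this assay, at which 3 of the 4 values shown sit.

Going by these compounds, whether chloro or methyl on this ring would keep a readable number remains open. So does whether any group there could give a lower number than fluoro.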